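The compounds below may be only part of what the source reports. "The series", "measured", "known", "first", "only" and "open" are said of these compounds alone.

Compound 3 `Cc1ccc(-c2cc(/N=C/N(C)C)n(-c3ccc(Br)cc3)n2)cc1` is measured in a functional assay on Jurkat cells (Homo sapiens) for inhibition, read by MTT assay, with a stated time of 72 h; a lower number here means a stronger inhibitor of growth, a higher number a weaker inhibitor of growth. For compound 3 the value > 100000 nM is only a limit of the assay, not a number (the limit of > 100000 nM in this assay, at which 1 of the 3 values shown sits). Compound 1 `Cc1ccc(-c2cc(N)n(-c3ccc(Br)cc3)n2)cc1` gives 45000 nM. The step of an at least 2.2-fold lower number from compound 3 to compound 1 (0.34 log units; beyond the scatter) comes with the change (one nitrogen atom in place of a group of 5 heavy atoms (3 carbon, 2 nitrogen; no ring), on an aromatic carbon). Compound 2 `CN(C)/C=N/c1c(C=O)c(-c2ccccc2)nn1-c1ccccc1` gives 23500 nM; the difference between its core and the core of compound 3 is not broken down here. Compound 4 `Nc1c(C=O)c(-c2ccccc2)nn1-c1ccccc1` carries the same kind of change, (one nitrogen atom in place of a group of 5 heavy atoms (3 carbon, 2 nitrogen; no ring), on an aromatic carbon), though the surroundings differ: here the changed carbon sits next to the ring atom that bears a formyl group and next to the ring atom that bears a phenyl group, whereas in compound 1 it sits next to the ring atom that bears a 4-bromophenyl group. Resting on the step of an at least 2.2-fold lower number from compound 3 to compound 1 (0.34 log units; beyond the scatter), the expected step is a 2.4-fold lower number from compound 2 to compound 4 (0.37 log units; beyond the scatter). The estimate for compound 4 is 10000 nM.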

Compound 4, concentration for 50% growth inhibition: 87300 nM
Beside the measured number, compound 4's estimate is 8.7-fold (0.94 log units) below it; the measured number lies above the stated range.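

On the core of compound 2, the swap to amino gives a 3.7-fold higher number from compound 2 to compound 4 (0.57 log units; beyond the scatter) in this assay, so here the change weakens growth inhibition, and the same swap does not carry over in size or direction from one core to the other: the same change on two cores in this assay, an at least 2.2-fold lower number (0.34 log units; beyond the scatter) from compound 3 to compound 1 and a 3.7-fold higher number (0.57 log units; beyond the scatter) from compound 2 to compound 4, at least 8.2-fold (0.91 log units) apart, beyond the scatter of two such steps

Compound 3 gives only a limit of the assay, > 100000 nM, so the size of its step is not fixed. Two pairs show that the core matters, but they do not show which part of it does or predict the step on a third core.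

The compounds shown leave open whether the formyl group, the phenyl group or the 4-bromophenyl group sets the direction of the step. They also leave open how a methylamino or acetylamino group would behave on this carbon.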